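This account rests on a few compounds, and the source may have more. Where it says the series, first, only, none or still open, it means among the compounds named here.

Measured compounds:
compound 1 `Nc1ccnc(-c2nn(Cc3ccccc3F)c3ncccc23)n1`: 270 nM; 265000 nM (2 entries)
compound 2 `Nc1nc(-c2nn(Cc3ccccc3F)c3ncccc23)ncc1C1CCC1`: 633000 nM

Compound 2, with the structure `Nc1nc(-c2nn(Cc3ccccc3F)c3ncccc23)ncc1C1CCC1`, is the starting point of this step. Among the measured compounds shown here, in a functional assay (aorta) with Oryctolagus cuniculus as the target (on this read-out higher numbers stand for weaker inhibition and lower numbers for stronger inhibition), compound 2 gives 633000 nM, the only number reported for it; a further entry for compound 2 carries no single number. Compound 1, with the structure `Nc1ccnc(-c2nn(Cc3ccccc3F)c3ncccc23)n1`, has two entries in this assay, 270 nM; 265000 nM (2 entries), and these lie far apart from each other, as the record the several entries of compound 1 in this assay, 270 nM; 265000 nM (2 entries) shows; the values of compound 1 and compound 2 therefore allow no simple comparison. Compound 3, with the structure `Nc1nc(-c2nn(Cc3ccccc3F)c3ncccc23)ncc1CC(F)(F)F`, has not yet been measured. It differs from compound 2 in one place: 2,2,2-trifluoroethyl in place of cyclobutyl on an aromatic carbon. For the measured compounds named here, no measured step bears on this change, so its size is not known from the data. The author expects the step of a 1.3-fold lower number from compound 2 to compound 3 (0.10 log units; within the scatter) in this assay to stay within the usual scatter, in no set direction. Compound 3 is therefore estimated at 500000 nM, with a range from 150000 nM to 2000000 nM.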

Compound 3, half-maximal inhibitory concentration: 508000 nM
For compound 3 the middle estimate is 1.0-fold (0.01 log units) below the measured one; low and high end bracket the measured number.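

In this assay the exchange of cyclobutyl for 2,2,2-trifluoroethyl gives a 1.2-fold lower number from compound 2 to compound 3 (0.10 log units; within the scatter), so at this aromatic carbon, ortho to an amino group, the two groups cannot be told apart on this read-out. Among the compounds shown here, this is the first measured step at this position, and it shows that a four-membered ring of carbon only and an open chain carrying three fluorine atoms read alike here, although they share neither ring nor element count. Whether either group differs from compound 1, which carries neither of them, cannot be read, because the entries of compound 1 lie too far apart to serve as a reference: the several entries of compound 1 in this assay, 270 nM; 265000 nM (2 entries)

The compounds shown leave open whether this level of the read-out holds for quite different groups on the same carbon, such as an amine, a carboxylic acid or a longer alkyl chain. They also leave open whether the exchange would read alike with a hydroxyl group standing in place of the amino group.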